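Widening the amide end of a thioether side chain

The compounds below may be only part of what the source reports. "The series", "measured", "known", "first", "only" and "open" are said of these compounds alone.

Compound 1 `Cc1c(C(=O)CSCCO)[n+]([O-])c2ccccc2[n+]1[O-]`: in an ADME assay on Vero cells (Chlorocebus sabaeus) for cytotoxicity, read by MTT assay, with a stated time of 72 h (a higher number here means that more compound is tolerated, a lower number that less compound is tolerated), compound 1 gives "not determined" (no result reported).
Compound 2 `Cc1c(C(=O)CSc2nccs2)[n+]([O-])c2ccccc2[n+]1[O-]`: in this assay compound 2 gives 50 ug/mL.
Compound 3 `CC(=O)NCCSCC(=O)c1c(C)[n+]([O-])c2ccccc2[n+]1[O-]`: in this assay compound 3 gives "not determined" (no result reported).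

Compound 3 therefore stands without a number of its own in this assay, and compound 1 is in the same position; only compound 2 carries a measured figure among the three. All three share the same core and differ only in the group hanging from the sulfur of the side chain.

Compound 4 `COc1ccc(C(=O)NCCSCC(=O)c2c(C)[n+]([O-])c3ccccc3[n+]2[O-])cc1` is built from compound 3 by the change (4-methoxyphenyl in place of methyl on a carbonyl carbon), that is, 4-methoxyphenyl in place of methyl on a carbonyl carbon. Among the compounds with values here, no pair of measured compounds shows this step, and compound 3 itself has no value to step from, so the expectation rests on the single number given by compound 2 in this assay. For this change the expected movement in this assay is small, if anything a slight shift towards less compound being tolerated, and not clearly beyond the usual scatter.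

Compound 4 is estimated to give about 30 ug/mL in this assay, with a plausible span from 8 ug/mL to 100 ug/mL.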

Compound 4, half-maximal cytotoxic concentration: > 100 ug/mL
Compound 4: a limit, no number; the forecaster's own chance of this, stated with the estimate: 20%; middle value at least 3.3-fold (0.52 log units) from the limit.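

In this assay compound 4 gives > 100 ug/mL, which is a limit of the assay and not a number. Within the data shown here, compound 3 has no number of its own, so no step from compound 3 to compound 4 can be read. The compounds shown leave open how far 4-methoxyphenyl in place of methyl on a carbonyl carbon shifts tolerance.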